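Nitro in place of cyano: compound 3 to compound 4

A few compounds are considered here, and "the series" means these few. Any claim that something is new, unique, unknown or untested is made for them only; others in the source may bear on it.

Of the compounds shown here, three have numbers so far in a functional assay on VCaP cells (Homo sapiens) for antiproliferative activity, read by propidium iodide staining, with a stated time of 96 h; a higher number here means a weaker inhibitor, a lower number a stronger inhibitor. Compound 1 (`CC(O)(CSc1ccc(S(F)(F)(F)(F)F)cc1)C(=O)Nc1ccc([N+](=O)[O-])c(C(F)(F)F)c1`) gives 10100 nM and compound 2 (`CC(O)(CSc1cccc(S(F)(F)(F)(F)F)c1)C(=O)Nc1ccc([N+](=O)[O-])c(C(F)(F)F)c1`) gives 9800 nM, two values within the scatter of each other. Compound 3 (`CC(O)(CSc1cccc(S(F)(F)(F)(F)F)c1)C(=O)Nc1ccc(C#N)cc1C(F)(F)F`) gives 30800 nM, the highest of the three numbers and beyond the scatter from both others, so it is the weakest inhibitor of the set.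

Compound 4 (`CC(O)(CSc1cccc(S(F)(F)(F)(F)F)c1)C(=O)Nc1ccc([N+](=O)[O-])cc1C(F)(F)F`) has not yet been measured in this assay. It departs from compound 3 in one place, nitro in place of cyano on an aromatic carbon. Going by the values given here, no measured pair shows this change alone, so the expectation rests on indirect evidence. Among the compounds with values here, compound 3 gives 30800 nM, and the two nitro compounds measured so far, compound 1 at 10100 nM and compound 2 at 9800 nM, both give lower numbers. A modest step toward a lower number, meaning a stronger inhibitor, is therefore expected. The expected step runs a 2.2-fold lower number from compound 3 to compound 4 (0.34 log units; beyond the scatter). For compound 4 the estimate is 14000 nM, with an expected range of 6500 nM to 30000 nM.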

Compound 4, half-maximal inhibitory concentration: 28800 nM
For compound 4 the middle estimate is 2.1-fold (0.31 log units) below the measured one; the range from low to high includes it.
By their numbers in this assay, from the lowest: compounds 2 and 1 (each within the scatter of the next); then compounds 4 and 3 (each within the scatter of the next).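

In this assay nitro in place of cyano, para to a large group and meta to a trifluoromethyl group, gives a 1.1-fold lower number from compound 3 to compound 4 (0.03 log units; within the scatter) and so the two groups cannot be told apart at this position. Going by these compounds alone, this is the first direct reading of the change, and it shows that the nitro group alone does not account for the lower numbers of compound 1 and compound 2, which also differ from compound 4 elsewhere on the core. Nothing available explains why this change leaves the number in place.

From the compounds shown here alone, whether any group at this position can separate itself from nitro and cyano stays open, for instance an amine or a carboxylic acid. Also open, going by these compounds, is whether the same change would read alike with a sulfone in place of the thioether sulfur.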